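The compounds below may be only part of what the source reports. "The series", "measured", "known", "first", "only" and "open" are said of these compounds alone.

Working notes on the series. In an assay on cells for displacement of a labelled ligand from corticotropin-releasing factor receptor 1 (Homo sapiens), with a stated time of 100 min (on this read-out higher numbers stand for weaker inhibition and lower numbers for stronger inhibition), compound 1 `CCCN(CC1CC1)C(=O)c1c(C)nc2n(-c3c(C)cc(C)cc3C)c(Cl)cn12` gives 61 nM, compound 3 `Cc1cc(C)c(-n2c(Cl)cn3c(CN(CCC(F)(F)F)Cc4ccccc4)c(C(F)(F)F)nc23)c(C)c1` gives 43 nM, and compound 2 `C=CCN(CC=C)Cc1c(C(F)(F)F)nc2n(-c3c(C)cc(C)cc3C)c(Cl)cn12` gives 13 nM. Compound 2 carries the lowest number of the three; its gaps to compound 3 and to compound 1 both lie beyond the scatter, so it stands as the strongest inhibitor of the measured set. Compound 4 `Cc1cc(C)c(-n2c(Cl)cn3c(CN4CCCC(C)C4)c(C(F)(F)F)nc23)c(C)c1` has not been measured. The change from compound 2 to compound 4 is 3-methylpiperidin-1-yl in place of diallylamino on a saturated chain carbon bound to an aromatic carbon. Among the compounds with values here, no measured pair in the set makes this kind of change, so the step must be guessed. The expectation is a small shift towards a weaker inhibition constant, a 1.9-fold higher number from compound 2 to compound 4 (0.28 log units; within the scatter), probably within the scatter. Compound 4 is therefore expected to give an estimated 25 nM, with a range from 8 nM to 80 nM in this assay.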

Compound 4, inhibition constant: 5800 nM
Compound 4: the middle estimate sits 230-fold (2.37 log units) below what was measured; the measured number lies above the stated range.
By their numbers in this assay, from the lowest: compound 2; then compounds 3 and 1 (each within the scatter of the next); then compound 4.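

On the saturated chain carbon bound to an aromatic carbon, 3-methylpiperidin-1-yl in place of diallylamino gives a 450-fold higher number from compound 2 to compound 4 (2.65 log units; beyond the scatter) in this assay and is far from a neutral swap. The two groups match in heavy atoms and hydrogen-bond acceptors, so this position responds to more than those counts, with the ring and the lost double bonds as the printed differences. No data here explain the loss.

From the compounds shown here alone, it remains open whether the ring or its methyl carries the step. A piperidin-1-yl without the methyl, or a dipropylamino group, on the same carbon would separate the two.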